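The source may report more compounds than this note shows. Statements on the series, on what has been measured and on what is new or still open speak of the compounds shown alone.

Of the compounds shown here, three sharing one core have been measured in a functional assay on MCF7 cells (Homo sapiens) for antiproliferative activity, read by MTT assay, with a stated time of 48 h; a lower number here means a stronger inhibitor, a higher number a weaker inhibitor. Compound 1 `Fc1ccc(C2=NN(c3nc(-c4ccc(C(F)(F)F)cc4)cs3)C(c3cccs3)C2)cc1` gives 1330 nM. Among the compounds with values here, compound 2 `Cc1ccc(C2=NN(c3nc(-c4ccc(C(F)(F)F)cc4)cs3)C(c3cccs3)C2)cc1` gives 31500 nM, and the only single-point step measured so far, a 24-fold higher number from compound 1 to compound 2 (1.37 log units; beyond the scatter), comes from exchanging one small aromatic group for another. Compound 3 `Brc1ccc(C2=NN(c3nc(-c4ccc(Br)cc4)cs3)C(c3cccs3)C2)cc1` gives 28300 nM. Among the three numbers compound 3 stands second highest: its nearest neighbour is compound 2, within the scatter, and its furthest is compound 1, well beyond it.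

Compound 4 `FC(F)(F)c1ccc(-c2csc(N3N=C(c4ccc(Br)cc4)CC3c3cccs3)n2)cc1` has not yet been measured. It differs from compound 3 by trifluoromethyl in place of bromo on an aromatic carbon. Within the data shown here, no measured step tests this exchange directly, because the one known step, a 24-fold higher number from compound 1 to compound 2 (1.37 log units; beyond the scatter), concerns a different pair of groups; compounds 1 and 2 do contain a trifluoromethyl, but they also differ from compound 4 in other respects, so their values give only weak guidance. A modest shift is therefore expected, if any beyond the scatter. Compound 4 is estimated at 15000 nM, with a range from 4000 nM to 60000 nM. This corresponds to an expected step of a 1.9-fold lower number from compound 3 to compound 4 (0.28 log units; within the scatter).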

Compound 4, half-maximal inhibitory concentration: 7810 nM
For compound 4 the middle estimate is 1.9-fold (0.28 log units) above the measured one; low and high end bracket the measured number.
By their numbers in this assay, from the lowest: compound 1; then compound 4; then compounds 3 and 2 (each within the scatter of the next).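

Placing trifluoromethyl where bromo stood gives a 3.6-fold lower number from compound 3 to compound 4 (0.56 log units; beyond the scatter) and shows that this site on the core also affects the number in this assay. With trifluoromethyl kept in place, the group on the other aromatic ring now has three measured members: bromo in place of methyl gives a 4.0-fold lower number from compound 2 to compound 4 (0.61 log units; beyond the scatter) and bromo in place of fluoro gives a 5.9-fold higher number from compound 1 to compound 4 (0.77 log units; beyond the scatter) as the matching change. Among these three compounds, bromo falls between fluoro and methyl, dividing the earlier large gap into two modest steps.

Going by these compounds, whether this order extends to other groups at either site, such as a methoxy, an amine or a carboxylic acid, remains open. Nothing available here accounts for the size or direction of these steps.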